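Compound 1 to compound 4: an aryl exchange

A few compounds are considered here, and "the series" means these few. Any claim that something is new, unique, unknown or untested is made for them only; others in the source may bear on it.

In an ADME assay on J774.A1 cells (Mus musculus) for cytotoxicity, read by MTT assay, with a stated time of 72 h (a lower number here means that less compound is tolerated, a higher number that more compound is tolerated), compound 1 `COc1cccc(-c2cc(-c3ccc(C4NC(=O)c5ccccc5N4)cc3)nc(N)n2)c1OC` gives > 400000 nM, which is a limit and not a number. Compound 2 `CC1(c2ccc(NC(c3ccc(Cl)cc3)c3nnnn3C(C)(C)C)cc2)NC(=O)c2ccccc2N1` gives > 400000 nM, which is also a limit. For compound 3 `CC(C)(C)n1nnnc1C(NCc1ccccc1)c1ccc(C2NC(=O)c3ccccc3N2)cc1` the result reads "not determined" (no result reported). The series therefore offers only (the limit of > 400000 nM in this assay, at which 2 of the 3 values shown sit).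

Compound 4 `Nc1nc(-c2ccc(Br)cc2)cc(-c2ccc(C3NC(=O)c4ccccc4N3)cc2)n1` differs from compound 1 by one exchange 4-bromophenyl in place of 2,3-dimethoxyphenyl on an aromatic carbon of a six-membered aromatic ring with 2 nitrogen.

Going by the values given here, no measured step between close pairs is available in this assay, so the expectation is loose: a modest move toward less compound being tolerated, possibly none beyond the scatter. The expected change is an at least 1.4-fold lower number from compound 1 to compound 4 (0.15 log units; that floor lies within the scatter). The estimate for compound 4 is 280000 nM, with an expected range of 80000 nM to 400000 nM.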

Compound 4, half-maximal cytotoxic concentration: 125000 nM
Compound 4: the middle estimate sits 2.2-fold (0.35 log units) above what was measured; low and high end bracket the measured number.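

Replacing 2,3-dimethoxyphenyl with 4-bromophenyl on this aromatic carbon gives an at least 3.2-fold lower number from compound 1 to compound 4 (0.50 log units; beyond the scatter) in this assay. As far as these compounds go, the aryl group at this position can therefore shift the result by more than the scatter, and the true size of the step stays open-ended since compound 1 carries a limit. Compound 4 is also the only compound shown with a single number, and the rest of the series stands as follows: the limit of > 400000 nM in this assay, at which 2 of the 4 values shown sit.

From the compounds shown here alone, whether the step follows the loss of the methoxy groups or the arrival of bromine remains open. A plain phenyl or a methoxyphenyl at this position would separate the two.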